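Adding a Carboxymethyl Group: What to Expect for Compound 4

This account rests on a few compounds, and the source may have more. Where it says the series, first, only, none or still open, it means among the compounds named here.

Measured compounds:
compound 1, `Cc1cccc2cc(/C=C3\SC(=S)NC3=O)c(Cl)nc12`, gives > 100 ug/mL; this is a limit of the assay, not a number.
compound 2, `O=C1NC(=S)S/C1=C\c1cc2cc(F)ccc2nc1Cl`, gives > 100 ug/mL; this too is a limit of the assay.
compound 3, `Cc1cccc2cc(/C=C3\SC(=S)N(CC(=O)O)C3=O)c(Cl)nc12`, gives > 100 ug/mL; again a limit of the assay.

All three values come from a toxicity assay on HeLa cells (Homo sapiens) for cytotoxicity, read by MTT assay, with a stated time of 48 h; a higher number here means a weaker inhibitor of growth, a lower number a stronger inhibitor of growth. None of them is a true number: each is a limit of the assay. Compound 3 is compound 1 with one change, (carboxymethyl in place of hydrogen on an amide-type nitrogen in a ring). As far as these compounds go, because both ends of this pair sit at a limit, the step that the two limits leave unreadable from compound 1 to compound 3 cannot be read, and its size stays unknown. The difference between the core of compound 1 and the core of compound 2 is not broken down here.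

Compound 4, `O=C(O)CN1C(=O)/C(=C/c2cc3cc(F)ccc3nc2Cl)SC1=S`, has not yet been measured. It stands to compound 2 exactly as compound 3 stands to compound 1: carboxymethyl in place of hydrogen on an amide-type nitrogen in a ring. The place of the change is the same in both pairs, so this is the same change made on a second core.

For the measured compounds named here, the only evidence available is the limit of > 100 ug/mL in this assay, at which 3 of the 3 values shown sit. With every measured compound, including the unchanged partner compound 2, at that limit, the step from compound 2 to compound 4 is expected to be a step that the limit leaves unreadable from compound 2 to compound 4, meaning no readable movement. Compound 4 is therefore estimated at 150 ug/mL in this assay, most probably reported again as a limit, with a plausible range from 70 ug/mL to 400 ug/mL.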

Compound 4, concentration for 50% growth inhibition: > 100 ug/mL
Compound 4 was reported as a limit (the forecaster's own chance of this, stated with the estimate: 85%); the middle value lies beyond the limit too.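

Compound 4 gives > 100 ug/mL, which is a limit of the assay and not a number. No size can be read for the carboxymethyl change, either from compound 2 to compound 4 or from compound 1 to compound 3: the limit of > 100 ug/mL in this assay, at which 4 of the 4 values shown sit. Left open is whether this change alters growth inhibition on either core, and how the core of compound 1 and the core of compound 2 compare in this assay at any concentration the limit conceals.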